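A few compounds are considered here, and "the series" means these few. Any claim that something is new, unique, unknown or untested is made for them only; others in the source may bear on it.

In a functional assay on PC-3 cells (Homo sapiens) for antiproliferative activity, read by WST assay, with a stated time of 3 days (on this read-out higher numbers stand for weaker inhibition and lower numbers for stronger inhibition), compound 1 (`CCCOc1c(-c2cc(OC)c(OC)c(OC)c2)oc2ccccc2c1=O`) gives 11800 nM, the lower of the two actual numbers in this small series. Compound 2 (`CCCCCCOc1c(-c2cc(OC)c(OC)c(OC)c2)oc2ccccc2c1=O`), with a longer chain, gives 29200 nM. Compound 3 (`CCCCCCCOc1c(-c2cc(OC)c(OC)c(OC)c2)oc2ccccc2c1=O`), with a longer chain still, reads > 50000 nM, and this value is a limit of the assay. The measured steps are a 2.5-fold higher number from compound 1 to compound 2 (0.39 log units; beyond the scatter) and an at least 4.2-fold higher number from compound 1 to compound 3 (0.62 log units; beyond the scatter), both beyond the scatter, whereas an at least 1.7-fold higher number from compound 2 to compound 3 (0.23 log units; that floor lies within the scatter) has a floor within it.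

Compound 4 (`COc1cc(-c2oc3ccccc3c(=O)c2OC(C)C)cc(OC)c1OC`) keeps the shared core and carries the same atoms joined differently: isopropyl in place of propyl on an oxygen on an aromatic ring, a change from propoxy to isopropoxy. Within the data shown here, no measured step makes this exact change. The steps above all extend the chain, while compound 4 does not, so they bear on it only indirectly, and no step beyond the scatter is expected in this assay. The expected change is a 1.1-fold higher number from compound 1 to compound 4 (0.04 log units; within the scatter). For compound 4 the estimated value is 13000 nM, within an expected range of 6000 nM to 30000 nM.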

Compound 4, half-maximal inhibitory concentration: 21200 nM
Compound 4: middle estimate off by 1.6-fold (0.21 log units), on the low side; the measured number falls inside the stated range.
By their numbers in this assay, from the lowest: compounds 1, 4 and 2 (each within the scatter of the next, the first and the last beyond it). At a limit, above all of these: compound 3.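

In this assay, the swap of propyl for isopropyl on an oxygen on an aromatic ring, which leaves the count of carbons unchanged, gives a 1.8-fold higher number from compound 1 to compound 4 (0.25 log units; within the scatter), so this assay does not separate the branched chain from the straight one. Against the longer chains, the same isopropyl group gives a 1.4-fold lower number from compound 2 to compound 4 (0.14 log units; within the scatter) and an at least 2.3-fold lower number from compound 3 to compound 4 (0.37 log units; beyond the scatter): only the second of these separates compound 4 from a longer chain, and it is a floor, not a measured size. Compound 3 stands at a limit of the assay, not at a number: the limit of > 50000 nM in this assay, at which 1 of the 4 values shown sits.

On these data alone, whether an ethyl or methyl group on this oxygen would read differently from propyl remains open. So does the effect of a tert-butyl group or a chain ending in an amine or a carboxylic acid at this position.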